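This account rests on a few compounds, and the source may have more. Where it says the series, first, only, none or still open, it means among the compounds named here.

Measured so far in an ADME assay for protein binding, using equilibrium dialysis, at pH 7.4, tested at 2 uM; on this read-out lower numbers stand for a smaller free fraction and higher numbers for a larger free fraction:
compound 1 `CC1CC=C(C(=O)N(c2cc(C#CC(C)(C)C)sc2C(=O)O)C(C)C)CC1`: 0.08
compound 2 `CC(C)N(c1cc(C#CC(C)(C)C)sc1C(=O)O)C(=O)[C@H]1CC[C@H](C)CC1`: 0.06
compound 3 `CC(C)N(C(=O)C1CCCCC1)c1cc(C#CC(C)(C)C)sc1C(=O)O`: 0.18

Compound 3, at 0.18, holds the highest number of the three. Next comes compound 4 `CC(C)N(C(=O)C1CCC(F)(F)CC1)c1cc(C#CC(C)(C)C)sc1C(=O)O`, with the change 4,4-difluorocyclohexyl in place of cyclohexyl on a carbonyl carbon.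

Going by the values given here, no measured step introduces fluorine, so the evidence is indirect. The closest is a 3.0-fold higher number from compound 2 to compound 3 (0.48 log units; beyond the scatter), where hydrogen replaces methyl on a saturated ring carbon. The step of a 2.3-fold higher number from compound 1 to compound 3 (0.35 log units; beyond the scatter) points the same way, while a 1.3-fold lower number from compound 1 to compound 2 (0.12 log units; within the scatter) stays within the scatter. Both methyl-bearing compounds therefore sit lower than the plain cyclohexyl of compound 3, but two compounds make a thin basis, and fluorine is not methyl. A change in the same lower direction is expected, though smaller than those steps and probably not beyond the scatter. The expected step is a 1.4-fold lower number from compound 3 to compound 4 (0.14 log units; within the scatter). For compound 4 the estimated value is 0.13, with an expected range from 0.07 to 0.24.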

Compound 4, unbound fraction: 0.4
Estimate against measurement, compound 4: 3.1-fold (0.49 log units) below, outside the stated range (above it).
By their numbers in this assay, from the lowest: compounds 2 and 1 (each within the scatter of the next); then compound 3; then compound 4.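

In this assay, the 4,4-difluorocyclohexyl group on this carbonyl carbon gives a 2.2-fold higher number from compound 3 to compound 4 (0.35 log units; beyond the scatter) and so moves the number in the opposite direction to the methyl-bearing rings, which both sit lower than cyclohexyl. Substitution on this ring therefore does not simply lower the number: the outcome depends on the group that enters, with a 6.7-fold higher number from compound 2 to compound 4 (0.82 log units; beyond the scatter) against 4-methylcyclohexyl and a 5.0-fold higher number from compound 1 to compound 4 (0.70 log units; beyond the scatter) against 4-methylcyclohex-1-en-1-yl. Nothing measured here accounts for this rise.

As far as these compounds go, it remains open whether a ring with a single fluorine, a hydroxyl or an amine in place of the two fluorines would move the number the same way. From the compounds shown here alone, it is also open whether a trifluoromethyl group on the ring would follow the fluorines or the methyl.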